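A few compounds are considered here, and "the series" means these few. Any claim that something is new, unique, unknown or untested is made for them only; others in the source may bear on it.

Measured compounds:
- compound 1 `CCCC1=C(OCCC(C)C)C(CCC)(CCC)C(=O)/C(=C(O)\C=C\c2ccccc2)C1=O`: 15.5 uM
- compound 2 `CCCC1=C(OCC(C)C)C(CCC)(CCC)C(=O)/C(=C(O)\C=C\c2ccccc2)C1=O`: 13.4 uM
- compound 3 `CCCC1=C(OC)C(CCC)(CCC)C(=O)/C(=C(O)\C=C\c2ccc(Br)cc2)C1=O`: "not determined" (no result reported)

These results come from a functional assay on HepG2 cells (Homo sapiens) for antiproliferative activity, read by sulforhodamine B assay, with a stated time of 3 days; a higher number here means that more compound is needed for the effect, a lower number that less compound is needed. There, compound 2 gives 13.4 uM, which lies within the scatter of compound 1 at 15.5 uM. Compound 3 has no usable number, so only these two values can be compared.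

The next compound is compound 4 `CCCOC1=C(CCC)C(=O)/C(=C(O)/C=C/c2ccccc2)C(=O)C1(CCC)CCC`, which has not yet been measured. It differs from compound 2 by hydrogen in place of methyl on a saturated chain carbon bound to two saturated chain carbons. Here, isobutoxy becomes propoxy, with hydrogen in place of methyl on a saturated chain carbon bound to two saturated chain carbons.

Among the compounds with values here, only one measured step bears on this change: a 1.2-fold lower number from compound 1 to compound 2 (0.06 log units; within the scatter). It involved isopropyl in place of isobutyl on the same oxygen-bound chain. With this single small step as the guide, no change beyond the scatter is expected in this assay, and no direction can be favoured. The expected result is a 1.0-fold higher number from compound 2 to compound 4 (0.02 log units; within the scatter). For compound 4 the estimated value is 14 uM, with an expected range from 8 uM to 25 uM.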

Compound 4, concentration for half-maximal effect: 8.3 uM
Beside the measured number, compound 4's estimate is 1.7-fold (0.23 log units) above it, and the stated range covers the measured number.
By their numbers in this assay, from the lowest: compounds 4, 2 and 1 (each within the scatter of the next).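

Propoxy, an unbranched chain with hydrogen in place of methyl on a saturated chain carbon bound to two saturated chain carbons, gives in this assay a 1.6-fold lower number from compound 2 to compound 4 (0.21 log units; within the scatter), so this change stays within the scatter. The wider step, methyl in place of isopropyl on a saturated chain carbon two bonds along the chain from the oxygen, gives a 1.9-fold lower number from compound 1 to compound 4 (0.27 log units; within the scatter), and thus all three ether chains with a number, branched or unbranched, lie within the scatter of one another. No measurement is at hand that could explain these numbers.

On these data alone, whether a longer chain such as decyl, or a chain carrying an amine or a carboxylic acid, would move the number beyond the scatter stays open. Compound 3 has no number, so steps to it cannot be read.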